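This account rests on a few compounds, and the source may have more. Where it says the series, first, only, none or still open, it means among the compounds named here.

Of the compounds shown here, three have so far been measured in a functional assay on A-375 cells (Homo sapiens) for antiproliferative activity; on this read-out lower numbers stand for stronger inhibition and higher numbers for weaker inhibition. Compound 1 `CO/N=C/c1c(N)ncnc1Oc1ccc2cccnc2c1` gives 886 nM in this assay. Compound 3 `CO/N=C/c1c(N)ncnc1Oc1ccc2c(ccn2C)c1` gives 326 nM. Compound 2 `CNCCO/N=C/c1c(N)ncnc1Oc1ccc2[nH]c(C)cc2c1F` gives 345 nM. Among these three numbers compound 2 holds the second highest; its nearest neighbour is compound 3, whose number lies within the scatter of its own, so nothing separates the two, while compound 1 stands furthest away with a higher number, a gap beyond the scatter.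

Compound 4 `Cc1cc2c(F)c(Oc3ncnc(N)c3/C=N/OCC3CCCCC3)ccc2[nH]1` has not yet been measured in this assay. It differs from compound 2 in one place: cyclohexyl in place of (methylamino)methyl on a saturated chain carbon bound to an oxygen on an unsaturated carbon. For the measured compounds named here, no measured pair in this set carries this exchange, so there is no direct precedent for its effect on this assay. The expected step is therefore estimated as a small one, a 1.6-fold higher number from compound 2 to compound 4 (0.20 log units; within the scatter), leaning toward a somewhat higher number but not clearly beyond the scatter. On that basis compound 4 is expected to give about 550 nM in this assay. The likely range for compound 4 is estimated to run from 150 nM to 2000 nM.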

Compound 4, half-maximal inhibitory concentration: 4920 nM
Beside the measured number, compound 4's estimate is 8.9-fold (0.95 log units) below it, and the stated range ends below it.
By their numbers in this assay, from the lowest: compounds 3 and 2 (each within the scatter of the next); then compound 1; then compound 4.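

In this assay, for the compounds shown here, putting cyclohexyl in place of (methylamino)methyl on a saturated chain carbon bound to an oxygen on an unsaturated carbon gives a 14-fold higher number from compound 2 to compound 4 (1.15 log units; beyond the scatter), a large step that shows this position is far from indifferent to the group it carries, something the earlier compounds, with no single-place step among them, could not show. The exchange alters several things at once: the open chain gives way to a six-membered ring of carbon only, the group grows in heavy atoms, and the nitrogen goes with its hydrogen-bond donor and acceptor, so this one step cannot tell which of these changes matters. Nothing measured here bears on the cause of the step.

The compounds shown leave open whether a nitrogen-containing ring such as a piperidine or a morpholine in place of cyclohexyl, or a longer chain ending in a dimethylamino group, would keep a number close to that of compound 2 or fall nearer that of compound 4. From the compounds shown here alone, it also remains open whether the same exchange would give a step of similar size on the cores of compound 1 and compound 3.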